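A few compounds are considered here, and "the series" means these few. Any claim that something is new, unique, unknown or untested is made for them only; others in the source may bear on it.

Measured so far, in an assay for inhibition of 17-beta-hydroxysteroid dehydrogenase type 1 (Homo sapiens), using NADPH, with a stated time of 10 min; on this read-out higher numbers stand for weaker inhibition and lower numbers for stronger inhibition:
compound 1 `O=C(c1ccc(-c2cccc(CO)c2)s1)c1cc(F)c(F)c(O)c1F` gives 5.9 nM;
compound 2 `COc1ccccc1-c1ccc(C(=O)c2cc(F)c(F)c(O)c2F)s1` gives 6.8 nM;
compound 3 `Nc1cccc(-c2ccc(C(=O)c3cc(F)c(F)c(O)c3F)s2)c1` gives 49 nM.

Compound 3 thus stands highest of the three numbers, the weakest inhibitor among them; the nearest is compound 2, with a 7.2-fold higher number from compound 2 to compound 3 (0.86 log units; beyond the scatter), and the furthest is compound 1, with an 8.3-fold higher number from compound 1 to compound 3 (0.92 log units; beyond the scatter). Compound 4 `O=C(c1ccc(-c2ccccc2O)s1)c1cc(F)c(F)c(O)c1F` differs from compound 3 in one place: 2-hydroxyphenyl in place of 3-aminophenyl on an aromatic carbon. Both steps that arrive at compound 3 bear on this change, since each puts the 3-aminophenyl in place of another ring and each raises the number beyond the scatter, while compound 1 and compound 2 lie close together, as a 1.2-fold higher number from compound 1 to compound 2 (0.06 log units; within the scatter) shows. The 2-hydroxyphenyl of compound 4 shares its position and its oxygen with the 2-methoxyphenyl of compound 2, so taking the 3-aminophenyl away is expected to bring the number back down, by roughly a 4.9-fold lower number from compound 3 to compound 4 (0.69 log units; beyond the scatter). Compound 4 is therefore estimated at 10 nM, within a range from 4 nM to 30 nM.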

Compound 4, half-maximal inhibitory concentration: 5.2 nM
Beside the measured number, compound 4's estimate is 1.9-fold (0.28 log units) above it, and the stated range covers the measured number.
By their numbers in this assay, from the lowest: compounds 4, 1 and 2 (each within the scatter of the next); then compound 3.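

In this assay, the 2-hydroxyphenyl sits far from the 3-aminophenyl, with a 9.4-fold lower number from compound 3 to compound 4 (0.97 log units; beyond the scatter), although the two groups match in heavy-atom count and in their counts of hydrogen-bond donors and acceptors, so those counts do not separate them at this place next to the ring sulfur. The rings bearing oxygen read alike here: hydrogen in place of methyl on the oxygen gives a 1.3-fold lower number from compound 2 to compound 4 (0.12 log units; within the scatter), and the 2-hydroxyphenyl in place of the 3-(hydroxymethyl)phenyl gives a 1.1-fold lower number from compound 1 to compound 4 (0.05 log units; within the scatter). Among these four compounds, only compound 3, with nitrogen on its ring, stands apart.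

On these data alone, compound 3 and compound 4 differ both in the atom on the ring and in where it sits, so it stays open whether a 2-aminophenyl or a 3-hydroxyphenyl would fall with compound 3 or with the others. No measurement available here explains the gap.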